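Removing a methyl from a diaryl ether thiosemicarbazone

The source may report more compounds than this note shows. Statements on the series, on what has been measured and on what is new or still open speak of the compounds shown alone.

Measured compounds in a physicochemical assay for lipophilicity, in phosphate buffer, measured as octanol-water partition, with a stated time of 24 h; on this read-out lower numbers stand for lower lipophilicity and higher numbers for higher lipophilicity:
compound 1, `S=C(N/N=C/c1ccc(Oc2ccccc2)cc1)Nc1ccc(Cl)cc1`: 5.64
compound 2, `Cc1ccc(Oc2ccc(/C=N/NC(=S)Nc3ccc(Cl)cc3)cc2)cc1`: 5.97
compound 3, `Cc1cc(Oc2ccc(/C=N/NC(=S)Nc3ccc(Cl)cc3)cc2)ccc1Cl`: 6.59

Compounds 1 and 2 differ in one place, (hydrogen in place of methyl on an aromatic carbon), and this gave a number 0.33 log units lower from compound 2 to compound 1 (beyond the scatter). Compound 3 differs from compound 2 in its outer ring, (4-chloro-3-methylphenyl in place of 4-methylphenyl on an oxygen on an aromatic ring), and stands highest of the three. Compound 4, `S=C(N/N=C/c1ccc(Oc2ccc(Cl)cc2)cc1)Nc1ccc(Cl)cc1`, is not yet measured; it differs from compound 3 by hydrogen in place of methyl on an aromatic carbon. This is the same kind of change as that from compound 2 to compound 1, but the place differs: in compound 2 the methyl sits para to a large group, whereas in compound 3 it sits ortho to a chloro group and meta to a large group. The step is expected to be a number 0.44 log units lower from compound 3 to compound 4 (beyond the scatter), resting on the step of a number 0.33 log units lower from compound 2 to compound 1 (beyond the scatter) seen for the same kind of change. Compound 4 is therefore estimated at 6.15, with a likely span from 5.7 to 6.55.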

Compound 4, partition coefficient: 6.2
Estimate against measurement, compound 4: 0.05 log units below, and the stated range covers the measured number.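

In this assay, removing the methyl gave a number 0.39 log units lower from compound 3 to compound 4 (beyond the scatter) and, on the outer ring without the chloro group, a number 0.33 log units lower from compound 2 to compound 1 (beyond the scatter) in the same direction, so this change carried over between these two pairs even though the methyl sits in a different place. Chloro in place of methyl gave a number 0.23 log units higher from compound 2 to compound 4 (within the scatter) while chloro in place of hydrogen gave a number 0.56 log units higher from compound 1 to compound 4 (beyond the scatter) on the same outer ring. Two pairs do not make a rule for the series, and nothing measured here explains the size of any of these steps.

The compounds shown leave open whether the step from methyl to hydrogen would hold on an outer ring carrying an amine or a carboxylic acid in place of the chloro group. They also leave open how an ethyl group in place of the methyl would compare.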